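The source may hold more compounds than are shown below. What is called first, only, known or untested is meant among the compounds shown, and "the series" means these compounds.

Compound 3 `CCOC(=O)c1nn(-c2ccc([N+](=O)[O-])cc2)c(=O)c2c(N)scc12` gives 13000 nM in an assay on CHO-K1 cells with adenosine receptor A1 (Homo sapiens) as the target; on this read-out higher numbers stand for an effect only at larger amounts of compound and lower numbers for an effect already at smaller amounts. Compound 1 `Cc1sc(N)c(C(=O)c2cccs2)c1C` gives 11200 nM and compound 2 `CCOC(=O)c1nn(-c2ccc(C(F)(F)F)cc2)c(=O)c2c(N)scc12` gives 8400 nM, so all three values lie within the scatter of one another and none is separated from compound 3. The change to compound 4 `CCOC(=O)c1nn(-c2ccc(OS(=O)(=O)C(F)(F)F)cc2)c(=O)c2c(N)scc12` is ((trifluoromethyl)sulfonyl)oxy in place of nitro on an aromatic carbon. Among the measured compounds shown here, the only measured step at this position is a 1.5-fold higher number from compound 2 to compound 3 (0.19 log units; within the scatter), which exchanged one group for another on the same aromatic carbon without moving the number beyond the scatter. On that basis the new exchange is expected to give no step beyond the scatter, as a 1.2-fold lower number from compound 3 to compound 4 (0.07 log units; within the scatter). Compound 4 is therefore estimated at 11000 nM, with a range from 4000 nM to 30000 nM.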

Compound 4, half-maximal effective concentration: 4900 nM
Compound 4: the middle estimate sits 2.2-fold (0.35 log units) above what was measured; measured number inside the range.
By their numbers in this assay, from the lowest: compounds 4, 2, 1 and 3 (each within the scatter of the next, the first and the last beyond it).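

In this assay, an exchange at this aromatic carbon now moves the number beyond the scatter: ((trifluoromethyl)sulfonyl)oxy in place of nitro gives a 2.7-fold lower number from compound 3 to compound 4 (0.42 log units; beyond the scatter) as a modest step. Set against trifluoromethyl, the same group gives a 1.7-fold lower number from compound 2 to compound 4 (0.23 log units; within the scatter) and stays within the scatter, so the separation holds only against nitro. Nothing measured here accounts for this step. Going by these compounds, whether an amine or a carboxylic acid on this carbon would stay within the scatter of these groups remains open. Also open, on these data alone, is whether replacing the ethyl ester would shift the number.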